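A few compounds are considered here, and "the series" means these few. Any claim that something is new, unique, unknown or untested is made for them only; others in the source may bear on it.

Of the compounds shown here, three built on one shared core have been measured in a functional assay, read by spectrophotometry, with a stated time of 15 min; on this read-out lower numbers stand for stronger inhibition and higher numbers for weaker inhibition. Compound 1 `Cc1nc2c3ccccc3ccc2c2nc3c(ccc4ccccc43)c(-c3cccc([N+](=O)[O-])c3)c12` gives 54.2 ug/mL, compound 2 `Cc1nc2c3ccccc3ccc2c2nc3c(ccc4ccccc43)c(-c3ccccc3)c12` gives 84.6 ug/mL, and compound 3 `Cc1nc2c3ccccc3ccc2c2nc3c(ccc4ccccc43)c(-c3ccc(O)cc3)c12` gives 44.1 ug/mL. Compound 3 carries the smallest of the three numbers, yet its separation from the others is slight: there is a 1.2-fold lower number from compound 1 to compound 3 (0.09 log units; within the scatter) and a 1.9-fold lower number from compound 2 to compound 3 (0.28 log units; within the scatter), and between the other two there is a 1.6-fold higher number from compound 1 to compound 2 (0.19 log units; within the scatter). None of these steps reaches beyond the usual scatter, so the three compounds cannot be ranked against one another on this evidence.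

Compound 4 `Cc1nc2c3ccccc3ccc2c2nc3c(ccc4ccccc43)c(-c3cc(O)nc4ccccc34)c12` is the next member to be tested. Relative to compound 3 its change is 2-hydroxyquinolin-4-yl in place of 4-hydroxyphenyl on an aromatic carbon. Two of the measured steps bear on this change: the addition of a hydroxy group in the step from compound 2 to compound 3, and the exchange of one aromatic group for another in the step from compound 1 to compound 3. Both stayed within the scatter, so no step beyond the scatter is expected in this assay for this further exchange, which amounts to a 1.0-fold higher number from compound 3 to compound 4 (0.01 log units; within the scatter). Compound 4 is therefore estimated to give 45 ug/mL, within a range from 22 ug/mL to 90 ug/mL.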

Compound 4, half-maximal inhibitory concentration: 44.8 ug/mL
Compound 4: the middle estimate sits 1.0-fold (0.00 log units) above what was measured; the range from low to high includes it.
By their numbers in this assay, from the lowest: compounds 3, 4, 1 and 2 (each within the scatter of the next).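

In this assay, this position, opposite the ring nitrogen of the shared core, accepts a group with a second aromatic ring: replacing 4-hydroxyphenyl, with 7 heavy atoms, by 2-hydroxyquinolin-4-yl, with 11 heavy atoms and a ring nitrogen, gives a 1.0-fold higher number from compound 3 to compound 4 (0.01 log units; within the scatter) and so leaves the read-out within the scatter. Among these compounds, until now, the position had carried only a single six-membered aromatic ring of carbon, and the larger group also stays within the scatter of the other two compounds, with a 1.9-fold lower number from compound 2 to compound 4 (0.28 log units; within the scatter) and a 1.2-fold lower number from compound 1 to compound 4 (0.08 log units; within the scatter), so the four compounds still cannot be ranked against one another. No supporting measurement is available that could account for this result.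

All four groups at this position are aromatic, so the compounds shown leave open whether an amine, a carboxylic acid or a longer alkyl chain there would move the number beyond the scatter. They also do not separate the part played by the hydroxy group of 2-hydroxyquinolin-4-yl from that of its fused ring, which a plain quinolin-4-yl group at the same place would address.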